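Trifluoromethoxy to 2,6-dimethylphenyl: working notes on the series

The compounds below may be only part of what the source reports. "The series", "measured", "known", "first", "only" and "open" are said of these compounds alone.

Measured in an ADME assay on Raji cells (Homo sapiens) for cytotoxicity, read by luminescence, with a stated time of 72 h (a higher number here means that more compound is needed for the effect, a lower number that less compound is needed), each value a limit and not a number:
Compound 1 `CCOC(=O)c1c(-c2cccc(OC)c2)[nH]c2cc(OC)ccc2c1=O` gives > 21500 nM
Compound 2 `CCOC(=O)c1c(-c2cccc(OC(F)(F)F)c2)[nH]c2cc(OC)ccc2c1=O` gives > 21500 nM
Compound 3 `CCOC(=O)c1c(-c2cccc(OC(F)(F)F)c2)[nH]c2cc(OC)c(F)cc2c1=O` gives > 21500 nM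

Compound 3 has no number and stands at the limit of > 21500 nM in this assay, at which 3 of the 3 values shown sit. Compound 4 `CCOC(=O)c1c(-c2cccc(-c3c(C)cccc3C)c2)[nH]c2cc(OC)c(F)cc2c1=O` carries 2,6-dimethylphenyl in place of trifluoromethoxy on an aromatic carbon, meta to a large group: 2,6-dimethylphenyl in place of trifluoromethoxy on an aromatic carbon.

Within the data shown here, two measured steps bear on this change: a step that the two limits leave unreadable from compound 1 to compound 2, at the same place on the ring, and a step that the two limits leave unreadable from compound 2 to compound 3, elsewhere on the shared core. Neither has a size that can be read, so neither gives a direction. The expectation therefore rests on compound 3, whose value of > 21500 nM is a limit. No step beyond the scatter is expected in this assay, and no direction can be given with confidence. The estimated step is an at least 1.0-fold lower number from compound 3 to compound 4 (0.03 log units; that floor lies within the scatter). Compound 4 is estimated at 20000 nM, with an expected range of 7000 nM to 40000 nM.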

Compound 4, half-maximal effective concentration: > 21500 nM
Compound 4: no number, only a limit; the forecaster's own chance of this, stated with the estimate: 70%; middle value at least 1.0-fold (0.03 log units) from the limit.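

In this assay compound 4 gives > 21500 nM, a limit and not a number, so no step from compound 3 to compound 4 can be read, and the series stays at: the limit of > 21500 nM in this assay, at which 4 of the 4 values shown sit.

The compounds shown leave open how much of any of them is needed for the effect, and whether 2,6-dimethylphenyl in place of trifluoromethoxy changes that amount at all.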